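Ethyl in Place of Hydrogen: Expecting a Fourth Compound

The source may hold more compounds than are shown below. What is called first, only, known or untested is meant among the compounds shown, and "the series" means these compounds.

Compound 1, `CC[C@H](C)[C@@H](NCC(=O)NNC(=O)COc1ccc(-c2nc3ccccc3s2)cc1OC)C(=O)O`, gives 1790 nM in a functional assay on MCF7 cells (Homo sapiens) for inhibition, read by MTT assay, with a stated time of 3 days; on this read-out lower numbers stand for stronger inhibition and higher numbers for weaker inhibition.
Compound 2, `COc1cc(-c2nc3ccccc3s2)ccc1OCC(=O)NNC(=O)CNC(=N)NCCC[C@H](N[N+](=O)[O-])C(=O)O`, gives 1960 nM in this assay.
Compound 3, `CCOC(=O)[C@H](NCC(=O)NNC(=O)COc1ccc(-c2nc3ccccc3s2)cc1OC)[C@@H](C)CC`, gives 2900 nM in this assay.

Of the compounds shown here, three have been measured, and all three give numbers that lie close together. Compounds 1 and 3 share one core and differ in a single place: ethyl in place of hydrogen on an oxygen next to a carbonyl group. That change made a step of a 1.6-fold higher number from compound 1 to compound 3 (0.21 log units; within the scatter), which is too small to be called a real change in potency. Compounds 1 and 2 have different cores, and the difference between the two cores is not broken down here; what their two values show is that they sit within the scatter of each other.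

Compound 4, `CCOC(=O)[C@H](CCCNC(=N)NCC(=O)NNC(=O)COc1ccc(-c2nc3ccccc3s2)cc1OC)N[N+](=O)[O-]`, has not yet been measured. It stands to compound 2 as compound 3 stands to compound 1: the change is ethyl in place of hydrogen on an oxygen next to a carbonyl group. The place of the change is the same in both pairs, so this is the same change made on a second core.

Among the measured compounds shown here, the only guide to what compound 4 will do is the step already seen for the same change. Because a 1.6-fold higher number from compound 1 to compound 3 (0.21 log units; within the scatter) stayed within the scatter, the expected step from compound 2 to compound 4 is of similar size, a 1.5-fold higher number from compound 2 to compound 4 (0.18 log units; within the scatter). On that basis compound 4 is estimated to give 3000 nM in this assay, with a likely range from 1500 nM to 6500 nM.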

Compound 4, half-maximal inhibitory concentration: 1950 nM
Compound 4: the middle estimate sits 1.5-fold (0.19 log units) above what was measured; low and high end bracket the measured number.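

On the second core, turning the carboxy group into ethoxycarbonyl gave a step of a 1.0-fold lower number from compound 2 to compound 4 (0.00 log units; within the scatter), so the swap of hydrogen for ethyl again left the number in this assay where repeated measurements could not tell it apart. Set side by side, the two steps do not differ by more than such measurements normally would: the same change on two cores in this assay, a 1.6-fold higher number (0.21 log units; within the scatter) from compound 1 to compound 3 and a 1.0-fold lower number (0.00 log units; within the scatter) from compound 2 to compound 4, 1.6-fold (0.21 log units) apart, within the scatter of two such steps. This shows that, on these two cores, the change behaved alike as far as this read-out can tell, but it does not show that ethyl has no effect at all, since a small real shift could hide inside the scatter, and two pairs say nothing firm about any further core.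

The compounds shown carry only hydrogen or ethyl on this oxygen, so it stays open whether methyl, a longer chain such as butyl, or a ring-bearing group such as benzyl would also leave the number in place. Going by these compounds, it also stays open what an amide in place of the ester or carboxylic acid would do, and whether the same change would track as closely on a core outside this small set.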